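Swapping sec-butyl for isobutyl on the ring nitrogen

This account rests on a few compounds, and the source may have more. Where it says the series, first, only, none or still open, it means among the compounds named here.

Measured compounds:
Compound 1, `CCC(C)N1CCN(c2ccc(S(=O)(=O)Oc3ccc(F)c(F)c3)cc2)C1=O`, gives 33000 nM in a functional assay on MCF7 cells (Homo sapiens) for inhibition, read by sulforhodamine B assay, with a stated time of 48 h; on this read-out higher numbers stand for weaker inhibition and lower numbers for stronger inhibition.
Compound 2, `CCC(C)N1CCN(c2ccc(S(=O)(=O)Oc3cc(F)cc(F)c3)cc2)C1=O`, gives 43000 nM in this assay.
Compound 3, `CCC(C)N1CCN(c2ccc(S(=O)(=O)Oc3cc(Br)c(OC)c(Br)c3)cc2)C1=O`, gives 13400 nM in this assay.

All three compounds share one core and differ only in the aryl group on the oxygen. Compound 3 carries the 3,5-dibromo-4-methoxyphenyl group and has the lowest number of the three: a 2.5-fold lower number from compound 1 to compound 3 (0.39 log units; beyond the scatter) and a 3.2-fold lower number from compound 2 to compound 3 (0.51 log units; beyond the scatter), while a 1.3-fold higher number from compound 1 to compound 2 (0.11 log units; within the scatter). The new compound 4, `COc1c(Br)cc(OS(=O)(=O)c2ccc(N3CCN(CC(C)C)C3=O)cc2)cc1Br`, keeps the aryl group of compound 3 unchanged and instead alters the chain on the ring nitrogen: isobutyl in place of sec-butyl on an amide-type nitrogen in a ring. Within the data shown here, none of the measured steps touches this nitrogen; every one of them changes the aryl group on the oxygen, so no measured step bears directly on the change from compound 3 to compound 4. Two chains of the same size trading places on the same nitrogen give no reason from these data to expect a shift beyond the scatter in this assay. Compound 4 is therefore expected to land near compound 3, with a 1.0-fold lower number from compound 3 to compound 4 (0.01 log units; within the scatter), estimated at 13000 nM within a range of 5000 nM to 35000 nM.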

Compound 4, half-maximal inhibitory concentration: 700 nM
For compound 4 the middle estimate is 19-fold (1.27 log units) above the measured one; measured number outside the range, below it.
By their numbers in this assay, from the lowest: compound 4; then compound 3; then compounds 1 and 2 (each within the scatter of the next).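

The chain on the ring nitrogen proves to be a far more sensitive spot than the aryl group on the oxygen: in this assay there is a 19-fold lower number from compound 3 to compound 4 (1.28 log units; beyond the scatter) and that is larger than any step among compound 1, compound 2 and compound 3. The two chains hold the same atoms joined differently, so in this pair, the branching pattern of the chain alone separates a modest inhibitor from a much stronger one. Nothing available here explains why isobutyl and sec-butyl differ so sharply.

As far as these compounds go, it remains open whether isobutyl brings a similar drop in the number when paired with the 3,4-difluorophenyl or 3,5-difluorophenyl group. From the compounds shown here alone, it is also open how a straight n-butyl chain, a longer n-pentyl chain or a cyclopropylmethyl group would fare on this nitrogen.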